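Adding a Second Phenyl to a Weak Aromatase Binder

A few compounds are considered here, and "the series" means these few. Any claim that something is new, unique, unknown or untested is made for them only; others in the source may bear on it.

Among the measured compounds shown here, compound 2, with the structure `c1ccc(Cn2nccn2)cc1`, has the higher of the two numbers so far in an assay on isolated protein for inhibition of Aromatase (Homo sapiens), read by fluorescence and colorimetric assay, with a stated time of 30 min (on this read-out higher numbers stand for weaker inhibition and lower numbers for stronger inhibition), giving 16300 nM. Its nearest neighbour is compound 1, with the structure `c1ccc(C(c2ccccc2)n2ccnn2)cc1`, which in this assay gives 4580 nM; the two compounds differ in more than one place, so this pair only shows that compound 1 sits lower by an amount beyond the scatter.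

Compound 3, with the structure `c1ccc(C(c2ccccc2)n2nccn2)cc1`, is not yet measured. It arises from compound 2 by a single change: phenyl in place of hydrogen on a saturated chain carbon bound to an aromatic carbon and an aromatic nitrogen. The carbon that carries the ring nitrogen thus holds two phenyl groups rather than one, as compound 1 does.

For the measured compounds named here, no measured pair isolates this change, so the expected size of the step rests on loose analogy. Going by the values given here, since the only compound in this assay that carries two phenyl groups, compound 1, gives 4580 nM, compound 3 is expected to move toward stronger inhibition, with an estimated step of a 3.3-fold lower number from compound 2 to compound 3 (0.51 log units; beyond the scatter). Compound 3 is therefore estimated at 5000 nM, within a range from 1500 nM to 16000 nM.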

Compound 3, half-maximal inhibitory concentration: 12000 nM
The estimate for compound 3 lay 2.4-fold (0.38 log units) below the measured number; measured number inside the range.
By their numbers in this assay, from the lowest: compound 1; then compounds 3 and 2 (each within the scatter of the next).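

Phenyl in place of hydrogen on a saturated chain carbon bound to an aromatic carbon and an aromatic nitrogen gives a step within the scatter (a 1.4-fold lower number from compound 2 to compound 3 (0.13 log units; within the scatter)), so with the 2H-1,2,3-triazol-2-yl group in place, the added ring does not separate the two compounds. The other new pair shows that the way the triazole is attached matters: 2H-1,2,3-triazol-2-yl in place of 1H-1,2,3-triazol-1-yl on a saturated chain carbon bound to two aromatic carbons gives a modest step beyond the scatter (a 2.6-fold higher number from compound 1 to compound 3 (0.42 log units; beyond the scatter)), so two phenyl groups alone do not account for the low number of compound 1. No supporting data on why either step has this size are available.

On these data alone, it remains open whether phenyl in place of hydrogen would give a larger step on a compound carrying the 1H-1,2,3-triazol-1-yl group. As far as these compounds go, it is also open whether a smaller group such as methyl, or a longer chain such as benzyl, on this same carbon would give a step beyond the scatter.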